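From Pyrrolidin-1-yl to 4-Methylpiperazin-1-yl on a Thiocarbonyl Carbon

A few compounds are considered here, and "the series" means these few. Any claim that something is new, unique, unknown or untested is made for them only; others in the source may bear on it.

Of the compounds shown here, three sharing one core have been measured. In a functional assay on MGC-803 cells (Homo sapiens) for antiproliferative activity, read by CCK-8 assay, with a stated time of 72 h, tested at 2 uM (a lower number here means a weaker effect, a higher number a stronger effect of the compound at the concentration tested), compound 1 `Nc1ccccc1NC(=O)c1ccc(CSC(=S)N2CCN(Cc3ccncc3)CC2)cc1` gives 18.4%, compound 2 `Nc1ccccc1NC(=O)c1ccc(CSC(=S)N2CCc3cc(Cl)ccc32)cc1` gives 57.7%, and compound 3 `Nc1ccccc1NC(=O)c1ccc(CSC(=S)N2CCCC2)cc1` gives 27%. Compound 3 thus stands second highest of the three: compound 1 lies within the scatter of it, while compound 2 is higher, the step being a number 30.7 percentage points lower from compound 2 to compound 3 (beyond the scatter).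

Compound 4 `CN1CCN(C(=S)SCc2ccc(C(=O)Nc3ccccc3N)cc2)CC1` differs from compound 3 in one place: 4-methylpiperazin-1-yl in place of pyrrolidin-1-yl on a thiocarbonyl carbon. For the measured compounds named here, the only measured step at this position is the large one from compound 2 to compound 3. Compound 1 also carries a piperazine on the thiocarbonyl carbon and gives 18.4%, within the scatter of compound 3, so for compound 4 a change of a number 5 percentage points lower from compound 3 to compound 4 (within the scatter) is expected, not beyond the scatter. Compound 4 is estimated at 22%, between 10% and 38%.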

Compound 4, a percentage reported as inhibition, at one concentration (the size of the read-out at that concentration, not a potency): 29.6%
For compound 4 the middle estimate is 7.6 percentage points below the measured one; measured number inside the range.
By their numbers in this assay, from the lowest: compounds 1, 3 and 4 (each within the scatter of the next, the first and the last beyond it); then compound 2.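

On the thiocarbonyl carbon, 4-methylpiperazin-1-yl and pyrrolidin-1-yl cannot be told apart in this assay (a number 2.6 percentage points higher from compound 3 to compound 4 (within the scatter)), while 5-chloro-2,3-dihydro-1H-indol-1-yl remains clearly ahead of the new group (a number 28.1 percentage points lower from compound 2 to compound 4 (beyond the scatter)). On the piperazine side, hydrogen in place of pyridin-4-yl on the saturated chain carbon bound to the ring nitrogen gives a step beyond the scatter (a number 11.2 percentage points higher from compound 1 to compound 4 (beyond the scatter)). No measurement shown explains these steps.

Whether the chlorine of compound 2 matters stays open, as the compounds shown include no 2,3-dihydro-1H-indol-1-yl without it. Going by these compounds, how a morpholine ring or an open-chain diethylamine would behave at this position also stays open.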